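Shortening the hydroxamic acid linker by one carbon

This account rests on a few compounds, and the source may have more. Where it says the series, first, only, none or still open, it means among the compounds named here.

Measured compounds:
- compound 1, `O=C(CCCCCCN(Cc1ccc(F)cc1)c1ncc(C(=O)NCCCn2ccnc2)s1)NO`: 19 nM
- compound 2, `CC(C)CCN(CCCCCCC(=O)NO)c1ncc(C(=O)NCc2cccnc2)s1`: 220 nM

Both were tested in an assay on isolated protein for inhibition of Nicotinamide phosphoribosyltransferase (Homo sapiens), read by fluorescence, with stated times of 5 min and 15 min; on this read-out lower numbers stand for stronger inhibition and higher numbers for weaker inhibition. Compound 1 has the lowest number of the two; compound 2 lies well beyond the usual scatter from it, so compound 1 is the stronger inhibitor of the pair.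

Compound 3, `O=C(CCCCCN(Cc1ccc(F)cc1)c1ncc(C(=O)NCCCn2ccnc2)s1)NO`, keeps the whole of compound 1 except for one change: hydroxycarbamoyl in place of (hydroxycarbamoyl)methyl on a saturated chain carbon, five bonds along the chain from a nitrogen on an aromatic ring. The chain that carries the hydroxycarbamoyl group is thus one carbon shorter. For the measured compounds named here, no measured pair shows the effect of such a shortening, so the direction cannot be read from the data; a step of a moderate size, most likely toward a weaker inhibition, is expected, although a result within the scatter is also possible. The expected step is a 2.1-fold higher number from compound 1 to compound 3 (0.32 log units; beyond the scatter). For compound 3 the estimated value in this assay is 40 nM, within a range from 12 nM to 130 nM.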

Compound 3, half-maximal inhibitory concentration: 7 nM
The estimate for compound 3 lay 5.7-fold (0.76 log units) above the measured number; the measured number lies below the stated range.
By their numbers in this assay, from the lowest: compound 3; then compound 1; then compound 2.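

In this assay, the chain that carries the hydroxycarbamoyl group can lose one carbon without any loss of inhibition: hydroxycarbamoyl in place of (hydroxycarbamoyl)methyl gives a 2.7-fold lower number from compound 1 to compound 3 (0.43 log units; beyond the scatter) and so a modest gain. For the compounds shown here, this is the first direct reading of chain length here, since compound 1 and compound 2 differ in more than one place and could not show it. No measurement shown offers a reason for the gain.

A still shorter chain or a longer chain than that of compound 1 remains untested among the compounds shown, so the best length is unknown. Also open, on these data alone, are whether a carboxylic acid or an amine could stand in place of the hydroxycarbamoyl group, and whether the same shortening would act alike on compound 2.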